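This account rests on a few compounds, and the source may have more. Where it says the series, first, only, none or still open, it means among the compounds named here.

Measured compounds:
compound 1 `O=C(/C=C/c1ccc(OCc2cn(Cc3cccc(Br)c3)nn2)cc1)c1ccc(Br)cc1`: 25%
compound 2 `O=C(/C=C/c1ccc(OCc2cn(Cc3ccc(Br)cc3)nn2)cc1)c1ccc(Br)cc1`: 22%

Going by the values given here, both were tested in a functional assay on HepG2 cells (Homo sapiens) for inhibition, read by MTT assay, with a stated time of 48 h, tested at 10 uM (on this read-out lower numbers stand for less inhibition of growth and higher numbers for more inhibition of growth at the one concentration tested), and compound 2 stands as the lower of the two numbers, though its only neighbour, compound 1, sits close by: the step of a number 3 percentage points lower from compound 1 to compound 2 (within the scatter) is within the usual scatter, so the two cannot be told apart.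

Compound 3 `O=C(/C=C/c1ccc(OCc2cn(Cc3cccc(F)c3)nn2)cc1)c1ccc(Br)cc1` has not yet been measured. It differs from compound 2 by 3-fluorophenyl in place of 4-bromophenyl on a saturated chain carbon bound to an aromatic nitrogen. Among the compounds with values here, the only measured step that bears on this place is the one from compound 1 to compound 2, which swapped the position of a bromine on the same ring and gave a number 3 percentage points lower from compound 1 to compound 2 (within the scatter), a change within the scatter. That single step offers no sign that changing the halogen or its position at this site moves the read-out, so no step beyond the scatter is expected in this assay for compound 3.

The estimate for compound 3 is therefore 23%, with a range from 10% to 38%. The step this expectation implies, a number 1 percentage points higher from compound 2 to compound 3 (within the scatter), is expected to stay within the scatter.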

Compound 3, percent growth inhibition at one concentration: 34%
Compound 3: the middle estimate sits 11 percentage points below what was measured; low and high end bracket the measured number.
By their numbers in this assay, from the lowest: compounds 2, 1 and 3 (each within the scatter of the next, the first and the last beyond it).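

In this assay, the change from 4-bromophenyl to 3-fluorophenyl on a saturated chain carbon bound to an aromatic nitrogen gives a number 12 percentage points higher from compound 2 to compound 3 (beyond the scatter), so the read-out can respond to a change at this place, which the shift of bromine alone did not show. Going from 3-bromophenyl to 3-fluorophenyl, fluoro in place of bromo on an aromatic carbon gives a number 9 percentage points higher from compound 1 to compound 3 (within the scatter), so exchanging the halogen alone cannot be told apart from repeat-to-repeat noise, and the one clear step appears only when both the halogen and its ring position differ. Neither single change clears the scatter on its own, so the step cannot be credited to either one, and nothing available here explains it.

As far as these compounds go, whether this ring would respond more strongly to a group other than a halogen, such as a methoxy group, an amine or a carboxylic acid, remains open. Also open, from the compounds shown here alone, is how these compounds would compare across a range of concentrations, since each number comes from a single concentration.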